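From Butoxy to 1-Acetamidoethoxy: A Solubility Estimate

The compounds below may be only part of what the source reports. "The series", "measured", "known", "first", "only" and "open" are said of these compounds alone.

Compound 1 (`CCCCSc1nc(N)c2ncn(Cc3c(F)ccc(Cl)c3F)c2n1`) with 25000 nM
Compound 2 (`CCCCOc1nc(N)c2ncn(Cc3c(F)ccc(C)c3F)c2n1`) with 50000 nM

Within the data shown here, both values come from a physicochemical assay for solubility, read by nephelometry (on this read-out higher numbers stand for higher solubility and lower numbers for lower solubility), and are the only measurements available so far. Compound 2 reads 50000 nM and compound 1 reads 25000 nM in this test. These numbers lie within the usual scatter of each other, so repeat measurements could not reliably rank the two compounds.

Compound 3 (`CC(=O)NC(C)Oc1nc(N)c2ncn(Cc3c(F)ccc(C)c3F)c2n1`) has not yet been measured. Compared with compound 2, it carries 1-acetamidoethyl in place of butyl on an oxygen on an aromatic ring.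

Among the measured compounds shown here, no two measured compounds differ in just one place, so the data contain no direct precedent for this swap. With no such guide, the expectation in this assay is a step no larger than the scatter, in neither direction with any confidence. The estimate therefore stays close to compound 2 (50000 nM), with a wide range. The expected change is small (a 1.2-fold higher number from compound 2 to compound 3 (0.08 log units; within the scatter)). For compound 3 the estimated value is 60000 nM (expected range from 20000 nM to 150000 nM).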

Compound 3, solubility: 100000 nM
Beside the measured number, compound 3's estimate is 1.7-fold (0.22 log units) below it; measured number inside the range.
By their numbers in this assay, from the lowest: compounds 1, 2 and 3 (each within the scatter of the next, the first and the last beyond it).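

In this assay, among these compounds, exchanging butyl for 1-acetamidoethyl on the oxygen gives a direct single-change comparison at this position for the first time: (a 2.0-fold higher number from compound 2 to compound 3 (0.30 log units; within the scatter)). The entering group has 6 heavy atoms, including 1 nitrogen and 1 oxygen, and brings 1 hydrogen-bond donor and 1 hydrogen-bond acceptor, whereas butyl has 4 heavy atoms, all carbon, and neither donor nor acceptor; even so, compound 2 and compound 3 cannot be reliably ranked on this read-out. No independent measurement is available to explain this outcome.

Going by these compounds, this single pair cannot show how other groups would read on the same oxygen, so it remains open whether an amine, a carboxylic acid or a longer chain would produce a step beyond the usual scatter. On these data alone, it also remains open whether replacing butyl with 1-acetamidoethyl would read the same way if the rest of the molecule were different.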